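From 4-chlorophenyl to pyridin-4-yl in the series

This account rests on a few compounds, and the source may have more. Where it says the series, first, only, none or still open, it means among the compounds named here.

The compounds share one core and differ in the group on the aromatic carbon next to the ring sulfur. In a functional assay on L1210 cells (Mus musculus) for antiproliferative activity (on this read-out higher numbers stand for weaker inhibition and lower numbers for stronger inhibition), compound 3 `COc1cc(C(=O)c2sc(-c3ccc(Cl)cc3)cc2N)cc(OC)c1OC` gives 93 nM. Compound 2 `COc1cc(C(=O)c2sc(-c3ccc(Br)cc3)cc2N)cc(OC)c1OC` gives 100 nM. The two stand level, with a step of a 1.1-fold lower number from compound 2 to compound 3 (0.03 log units; within the scatter). Compound 1 `COc1cc(C(=O)c2sc(-c3ccc(-c4ccccc4)cc3)cc2N)cc(OC)c1OC` gives > 10000 nM, which is a limit of the assay and not a number.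

Compound 4 `COc1cc(C(=O)c2sc(-c3ccncc3)cc2N)cc(OC)c1OC` carries pyridin-4-yl in place of 4-chlorophenyl on an aromatic carbon. Among the measured compounds shown here, no measured compound has a ring with a hetero atom at this carbon, so the evidence is indirect. Two large steps, an at least 100-fold lower number from compound 1 to compound 2 (2.00 log units; beyond the scatter) and an at least 100-fold lower number from compound 1 to compound 3 (2.03 log units; beyond the scatter), show that the read-out in this assay can respond strongly to the group at this carbon. The swap of one halogen for the other, a 1.1-fold lower number from compound 2 to compound 3 (0.03 log units; within the scatter), shows no such response. For the measured compounds named here, compound 3 therefore offers a good starting number, but the only measured group without a halogen lies far from it, as an at least 100-fold lower number from compound 1 to compound 3 (2.03 log units; beyond the scatter) shows. The expected change is a move to a higher number, beyond the scatter, though smaller than the steps from compound 1. The estimated step is an 8.6-fold higher number from compound 3 to compound 4 (0.93 log units; beyond the scatter). For compound 4 the estimate is 800 nM, with an expected range of 150 nM to 6000 nM.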

Compound 4, half-maximal inhibitory concentration: 1810 nM
Compound 4: middle estimate off by 2.3-fold (0.35 log units), on the low side, and the stated range covers the measured number.
By their numbers in this assay, from the lowest: compounds 3 and 2 (each within the scatter of the next); then compound 4. At a limit, above all of these: compound 1.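

In this assay, the replacement of 4-chlorophenyl by pyridin-4-yl is a large step, a 19-fold higher number from compound 3 to compound 4 (1.29 log units; beyond the scatter), and the comparison with the bromo compound agrees, an 18-fold higher number from compound 2 to compound 4 (1.26 log units; beyond the scatter). The earlier compounds shown here showed a strong response only when a halogen gave way to phenyl, whereas here the position also responds when one six-membered aromatic ring replaces another, with the chlorine gone and a ring nitrogen, counted as a hydrogen-bond acceptor, in its place. Compound 1 remains a limit and not a number, which leaves compound 4 as the only compound without a halogen on this ring to give a number: the limit of > 10000 nM in this assay, at which 1 of the 4 values shown sits.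

The step from compound 3 to compound 4 combines the loss of the chlorine with the entry of the ring nitrogen, and the compounds shown cannot divide it between the two. An unsubstituted phenyl at this carbon would separate these two changes, while pyridin-3-yl would test where the ring nitrogen stands and 4-methoxyphenyl would test a group other than a halogen on a carbon-only ring.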